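Amide nitrogen substituent change in a nitro-sulfone series

The compounds below may be only part of what the source reports. "The series", "measured", "known", "first", "only" and "open" are said of these compounds alone.

Compound 1 `CS(=O)(=O)c1ccc(C(=O)N2CCC(C(=O)N(Cc3ccccc3)c3ccccc3)CC2)cc1[N+](=O)[O-]` is the reference point. In an assay on isolated protein for inhibition of thyroid hormone receptor alpha (Homo sapiens), read by fluorescence polarization (on this read-out lower numbers stand for stronger inhibition and higher numbers for weaker inhibition), compound 1 gives > 60000 nM, a limit of the assay rather than a number. Within the data shown here, compound 2 `CN(Cc1cccc(F)c1)C(=O)CCCNC(=O)c1ccc(S(C)(=O)=O)c([N+](=O)[O-])c1` is the only other measured analogue. In this assay compound 2 gives > 60000 nM, again only a limit. The whole evidence so far is the limit of > 60000 nM in this assay, at which 2 of the 2 values shown sit. Going by these compounds, compound 3 `CN(Cc1ccccc1)C(=O)C1CCN(C(=O)c2ccc(S(C)(=O)=O)c([N+](=O)[O-])c2)CC1` is untested; it differs from compound 1 by methyl in place of phenyl on an amide-type nitrogen. Among the measured compounds shown here, no measured pair shows this change, so the expected step of a number no higher from compound 1 to compound 3 (the limit leaves the size open) is put at none beyond the scatter. Compound 3 is thus expected near 60000 nM, between 20000 nM and 200000 nM, most probably again reported as a limit.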

Compound 3, half-maximal inhibitory concentration: > 60000 nM
Compound 3 gave a limit, no number (the forecaster's own chance of this, stated with the estimate: 80%); the middle value lies on the limit itself.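

In this assay compound 3 gives > 60000 nM, a limit and not a number. Compound 1 is also only a limit, so the step between compound 1 and compound 3 cannot be read. The compounds shown leave open whether any analogue of this series gives a measurable value.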